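This account rests on a few compounds, and the source may have more. Where it says the series, first, only, none or still open, it means among the compounds named here.

Measured compounds:
- compound 1 `CC(=O)c1cccn1CCCN1CCN(c2ccc(F)cc2)CC1`: 16%
- compound 2 `CC(=O)c1cccn1CCCN1CCN(c2ccc(C)cc2)CC1`: 7%

In a functional assay on the whole organism (Abdomen, strain Swiss) for inhibition, with Mus musculus as the target, with stated times of 30 min, 10 min and 5 min, at a dose of 20 mg/kg by the oral route (on this read-out lower numbers stand for a weaker effect and higher numbers for a stronger effect at the one dose given), compound 2 gives 7%, and compound 1 gives 16%. For the measured compounds named here, the one measured step, a number 9 percentage points lower from compound 1 to compound 2 (within the scatter), is within the scatter, so the two compounds stand together at the low end of this read-out and cannot be told apart. Compound 3 `CC(=O)c1cccn1CCCN1CCN(c2ccc([N+](=O)[O-])cc2)CC1` differs from compound 2 in a single place: nitro in place of methyl on an aromatic carbon. Going by the values given here, the only measured step that touches this position is the fluoro-to-methyl swap, a number 9 percentage points lower from compound 1 to compound 2 (within the scatter), which stayed within the scatter; nothing has been measured with a nitro group. From that small step, no move beyond the scatter is expected for the nitro change. Compound 3 is estimated at 10%, with a range from 0% to 30%. The step of a number 3 percentage points higher from compound 2 to compound 3 (within the scatter) is therefore expected to be small.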

Compound 3, a percentage reported as inhibition, in the whole organism at one dose (the size of the read-out at that dose, not a potency): 11%
The estimate for compound 3 lay 1 percentage points below the measured number; low and high end bracket the measured number.
By their numbers in this assay, from the lowest: compounds 2, 3 and 1 (each within the scatter of the next).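

In this assay, a much larger group with hydrogen-bond acceptors, nitro in place of methyl, gives a number 4 percentage points higher from compound 2 to compound 3 (within the scatter), and nitro in place of fluoro gives a number 5 percentage points lower from compound 1 to compound 3 (within the scatter). This place on the aromatic ring, para to a large group, has therefore now held three different groups, and none of the steps among compounds 1, 2 and 3 goes beyond the scatter, so the read-out does not separate these groups at this one dose. No measurement is available that could explain this insensitivity.

Going by these compounds, it remains open whether a different kind of group at this place, such as an amine or a carboxylic acid, would move the read-out beyond the scatter. Equally open, on these data alone, is whether a change elsewhere in the shared core, such as a longer chain, would do so.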